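Swapping the aryl group on the shared core: compound 3

A few compounds are considered here, and "the series" means these few. Any claim that something is new, unique, unknown or untested is made for them only; others in the source may bear on it.

Of the compounds shown here, two sharing one core have been measured. Compound 1 `CC#CC(CC(=O)O)c1ccc(OCc2ccc3nc(-c4ccc(C(C)C)cc4)cn3c2)cc1` gives 528 nM in an assay on isolated protein for agonist activity at Free fatty acid receptor 1 (Homo sapiens); on this read-out higher numbers stand for an effect only at larger amounts of compound and lower numbers for an effect already at smaller amounts. Compound 2 `CC#CC(CC(=O)O)c1ccc(OCc2ccc3nc(-c4ccccc4F)cn3c2)cc1` gives 583 nM in this assay. The only difference between them is the aryl group on the shared core, 2-fluorophenyl in compound 2 in place of 4-isopropylphenyl in compound 1, and the step of a 1.1-fold higher number from compound 1 to compound 2 (0.04 log units; within the scatter) shows that this exchange left the read-out essentially unchanged. Compound 2 thus stands together with compound 1, the two values separated only by that step within the scatter.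

Compound 3 `CC#CC(CC(=O)O)c1ccc(OCc2ccc3nc(-c4cccc(C)c4)cn3c2)cc1` changes the same aryl group once more: 3-methylphenyl in place of 2-fluorophenyl on an aromatic carbon. Going by the values given here, the one measured step that bears on this, a 1.1-fold higher number from compound 1 to compound 2 (0.04 log units; within the scatter), exchanged an aryl group at the same position and stayed within the scatter. On that single precedent no step beyond the scatter is expected from compound 2 to compound 3, and the estimated step is a 1.0-fold lower number from compound 2 to compound 3 (0.02 log units; within the scatter). Compound 3 is therefore expected to give about 560 nM in this assay, with a plausible range from 280 nM to 1120 nM.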

Compound 3, half-maximal effective concentration: 1050 nM
Compound 3: the middle estimate sits 1.9-fold (0.27 log units) below what was measured; low and high end bracket the measured number.
By their numbers in this assay, from the lowest: compounds 1, 2 and 3 (each within the scatter of the next).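

With compound 3, a third aryl group has been placed on the aromatic carbon of the five-membered ring in the shared core, and in this assay the exchange of 2-fluorophenyl for 3-methylphenyl still stays inside the scatter (a 1.8-fold higher number from compound 2 to compound 3 (0.26 log units; within the scatter)). The comparison with the 4-isopropylphenyl group also stays inside it (a 2.0-fold higher number from compound 1 to compound 3 (0.30 log units; within the scatter)), so 2-fluorophenyl, 3-methylphenyl and 4-isopropylphenyl cannot be told apart here, even though they carry different groups at different places on the phenyl ring, and these two steps are larger than the first one but are still no measured difference. No measurement is at hand that could explain why these numbers lie so close together.

Going by these compounds, what remains open is whether any group at this position moves the number beyond the scatter, for example a plain phenyl, a phenyl carrying an amine or a carboxylic acid, or a small alkyl chain in place of the ring. On these data alone, it is also open whether moving one substituent around the ring matters, as in 4-methylphenyl or 2-methylphenyl compared with 3-methylphenyl.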